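A few compounds are considered here, and "the series" means these few. Any claim that something is new, unique, unknown or untested is made for them only; others in the source may bear on it.

Two compounds of the series have numbers in an assay on isolated protein for displacement of a labelled ligand from melanin-concentrating hormone receptor 1 (Homo sapiens); a lower number here means a stronger inhibitor, a higher number a weaker inhibitor. Compound 1 `CCCc1ccc(/C=C/C(=O)Nc2ccc3nc(CCC)cc(N)c3c2)cc1` gives 4 nM. For the measured compounds named here, compound 2 `CCCc1cc(N)c2cc(NC(=O)/C=C/c3ccc(O)cc3)ccc2n1` gives 1100 nM, the highest of the two numbers; its only neighbour is compound 1, reached through the single step recorded so far, a 280-fold higher number from compound 1 to compound 2 (2.44 log units; beyond the scatter), which is the one step that bears on the question below. Compound 3 `CCCc1cc(N)c2cc(NC(=O)/C=C/c3ccccc3Cl)ccc2n1` is not yet measured. It differs from compound 2 in one place: 2-chlorophenyl in place of 4-hydroxyphenyl on a double-bonded chain carbon bound to a double-bonded chain carbon. Going by the values given here, the hydroxy that leaves here is the group whose arrival drove the step from compound 1 upward, so its removal points toward a lower number for compound 3; yet the propyl of compound 1 does not return, a chlorine enters instead, and no measured pair covers that exchange, so a full return to the number of compound 1 is not assumed. The expected step is a 22-fold lower number from compound 2 to compound 3 (1.34 log units; beyond the scatter). For compound 3 the estimate in this assay is 50 nM, with a range from 8 nM to 300 nM.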

Compound 3, half-maximal inhibitory concentration: 120 nM
Estimate against measurement, compound 3: 2.4-fold (0.38 log units) below; the measured number falls inside the stated range.
By their numbers in this assay, from the lowest: compound 1; then compound 3; then compound 2.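

At this place on the double-bonded chain carbon, 2-chlorophenyl in this assay recovers part of the loss seen with 4-hydroxyphenyl, with a 9.2-fold lower number from compound 2 to compound 3 (0.96 log units; beyond the scatter) on this exchange. The recovery is incomplete, with a 30-fold higher number from compound 1 to compound 3 (1.48 log units; beyond the scatter) remaining when 2-chlorophenyl replaces 4-propylphenyl, so removing the hydroxy does not by itself restore the number of compound 1 and the group entering in its place still matters. Nothing on hand explains either step.

The compounds shown do not separate the effect of the chlorine from that of its placement on the ring, and 4-chlorophenyl would give the direct comparison with both compound 1 and compound 2. On these data alone, whether 4-methoxyphenyl, which keeps the oxygen of the hydroxy but not its hydrogen, would fall nearer compound 1 or compound 2 also remains open.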